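Swapping 3-chlorophenyl for vinyl on compound 1

The compounds below may be only part of what the source reports. "The series", "measured", "known", "first", "only" and "open" are said of these compounds alone.

In a functional assay on RAW264.7 cells (Mus musculus) for inhibition, read by Griess assay, with stated times of 2 h and 24 h (a lower number here means a stronger inhibitor, a higher number a weaker inhibitor), compound 1 `COc1ccc([C@@H]2CC(=O)c3c(O)cc(OCc4cn(Cc5cccc(Cl)c5)nn4)cc3O2)cc1O` gives 18200 nM, the highest of the three numbers measured, which makes it the weakest inhibitor so far. Compound 3 `CCCCn1cc(COc2cc(O)c3c(c2)O[C@H](c2ccc(OC)c(O)c2)C/C3=N\O)nn1` gives 8900 nM, and compound 2 `COc1ccc([C@@H]2C/C(=N\O)c3c(O)cc(OCc4cn(Cc5ccccc5F)nn4)cc3O2)cc1O` gives 5710 nM. Compound 4 `C=CCn1cc(COc2cc(O)c3c(c2)O[C@H](c2ccc(OC)c(O)c2)CC3=O)nn1` is still unmeasured. It differs from compound 1 as follows: vinyl in place of 3-chlorophenyl on a saturated chain carbon bound to an aromatic nitrogen. One measured step offers a rough parallel, also a ring replaced by a chain at that place: a 1.6-fold higher number from compound 2 to compound 3 (0.19 log units; within the scatter). It stays within the scatter, though its compounds differ from compound 1 elsewhere. The expected step, a 1.1-fold lower number from compound 1 to compound 4 (0.06 log units; within the scatter), is therefore none beyond the scatter in this assay. The estimate for compound 4 is 16000 nM, with an expected range from 7000 nM to 40000 nM.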

Compound 4, half-maximal inhibitory concentration: 13800 nM
The estimate for compound 4 lay 1.2-fold (0.06 log units) above the measured number; the range from low to high includes it.
By their numbers in this assay, from the lowest: compounds 2, 3, 4 and 1 (each within the scatter of the next, the first and the last beyond it).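

In this assay, trading the seven-heavy-atom 3-chlorophenyl for the two-carbon vinyl gives a 1.3-fold lower number from compound 1 to compound 4 (0.12 log units; within the scatter), so on the core of compound 1 this place accepts the loss of the aromatic ring with no change beyond the scatter. The same holds for the ring-to-chain swap a 1.6-fold higher number from compound 2 to compound 3 (0.19 log units; within the scatter), which has a different core. No measurement here explains this tolerance. Still open, on these data alone, is whether an amine or a carboxylic acid at this place would move the number beyond the scatter.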